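Substituent Swap at the Aminated Ring Carbon

A few compounds are considered here, and "the series" means these few. Any claim that something is new, unique, unknown or untested is made for them only; others in the source may bear on it.

Compounds measured so far in a functional assay on SF-268 cells (Homo sapiens) for cytotoxicity, read by MTT assay, with a stated time of 3 days; on this read-out higher numbers stand for weaker inhibition and lower numbers for stronger inhibition:
Compound 1 `N#Cc1c(O)nc(SCc2nc3ccccc3[nH]2)nc1-c1ccccc1`: 3.2 nM
Compound 2 `N#Cc1c(Cl)nc(SCc2nc3ccccc3[nH]2)nc1-c1ccccc1`: 3.2 nM
Compound 3 `N#Cc1c(Nc2ccccn2)nc(SCc2nc3ccccc3[nH]2)nc1-c1ccccc1`: 6.75 nM

Compound 3 stands at the highest of the three numbers. Its two neighbours lie the same distance away: a 2.1-fold higher number from compound 1 to compound 3 (0.32 log units; beyond the scatter) and a 2.1-fold higher number from compound 2 to compound 3 (0.32 log units; beyond the scatter), both modest but beyond the scatter. Compounds 1 and 2 themselves sit together: no change at the digits printed from compound 1 to compound 2 (within the scatter).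

Compound 4 `CN1CCN(c2nc(SCc3nc4ccccc4[nH]3)nc(-c3ccccc3)c2C#N)CC1` has not yet been measured. It differs from compound 3 in one place: 4-methylpiperazin-1-yl in place of (pyridin-2-yl)amino on an aromatic carbon.

Among the compounds with values here, no measured step covers this particular exchange. The two steps that bear on it, from compound 1 and from compound 2 to compound 3, show that three different groups at the same ring carbon all give numbers within about one modest step of each other. On that basis one can only expect that a fourth group at the same place stays in the same region, with no strong reason to predict a shift in either direction beyond the scatter. For compound 4 the expected step is therefore a 1.2-fold lower number from compound 3 to compound 4 (0.09 log units; within the scatter), essentially none. Compound 4 is estimated at 5.5 nM in this assay, with a range from 2 nM to 16 nM.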

Compound 4, half-maximal inhibitory concentration: 6.9 nM
Beside the measured number, compound 4's estimate is 1.3-fold (0.10 log units) below it; the measured number falls inside the stated range.
By their numbers in this assay, from the lowest: compounds 1 and 2 (each within the scatter of the next); then compounds 3 and 4 (each within the scatter of the next).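

In this assay, the exchange at this aromatic carbon gives a 1.0-fold higher number from compound 3 to compound 4 (0.01 log units; within the scatter), even though the group that leaves has an aromatic ring and a hydrogen-bond donor, while the group that enters has a non-aromatic ring and no such donor. So neither the aromatic ring of the (pyridin-2-yl)amino group nor its donor is needed to keep the number where it stood with compound 3, and the measured step from chloro to 4-methylpiperazin-1-yl gives a 2.2-fold higher number from compound 2 to compound 4 (0.33 log units; beyond the scatter), while the one from hydroxy gives a 2.2-fold higher number from compound 1 to compound 4 (0.33 log units; beyond the scatter), both modest but beyond the scatter. The four compounds thus form two groups, with chloro and hydroxy together and the two larger amine substituents together, but no measurement shown here accounts for that split.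

The compounds shown leave open whether a small open-chain amine such as dimethylamino, or a carboxylic acid, at this ring carbon would stay with either group. They also leave open whether the same tolerance holds once the phenyl group on the shared core is replaced, since all four compounds carry it unchanged.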